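The source may report more compounds than this note shows. Statements on the series, on what has been measured and on what is new or still open speak of the compounds shown alone.

Measured compounds:
Compound 1 `N#Cc1ccc(CN2CCC(NC(=O)COc3ccc4c(=O)c(-c5ccccc5)coc4c3)CC2)cc1` — in a functional assay on HepG2 cells (Homo sapiens) for cytotoxicity, read by MTT assay, with a stated time of 72 h (on this read-out lower numbers stand for stronger inhibition and higher numbers for weaker inhibition), compound 1 gives only the assay limit > 20000 nM.
Compound 2 `O=C(COc1ccc2c(=O)c(-c3ccccc3)coc2c1)N1CCN(Cc2ccccc2)CC1` — in this assay compound 2 gives only the assay limit > 20000 nM.
Compound 3 `O=C(COc1ccc2c(=O)cc(-c3ccccc3)oc2c1)NC1CCN(Cc2ccccc2)CC1` — in this assay compound 3 gives 16700 nM.

Within the data shown here, compound 3 holds the only numerical value in this set; the other two entries are limits, as stated in the limit of > 20000 nM in this assay, at which 2 of the 3 values shown sit. Its standing is therefore weak inhibition, close to the edge of what the read-out resolves, and no ranking against compound 1 or compound 2 can be drawn from a number against a limit.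

Compound 4 `O=C(COc1ccc2c(=O)cc(-c3ccccc3)oc2c1)NC1CCN(C(=O)c2ccccc2)CC1` is the next structure to be measured in this assay. It differs from compound 3 in one place: benzoyl in place of benzyl on an amine nitrogen in a ring. Among the measured compounds shown here, no measured step is available for this kind of exchange anywhere in the set, so no direction can be borrowed. Given that compound 3 already sits near the limit, the expected step of a 1.2-fold higher number from compound 3 to compound 4 (0.08 log units; within the scatter) is none beyond the scatter, with a real chance that only a limit is reported. Compound 4 is estimated at 20000 nM, within a range from 8000 nM to 50000 nM.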

Compound 4, half-maximal inhibitory concentration: > 20000 nM
Compound 4: a limit, no number (the forecaster's own chance of this, stated with the estimate: 55%); the middle value lies on the limit itself.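

In this assay, benzoyl in place of benzyl on an amine nitrogen in a ring gives an at least 1.1-fold higher number from compound 3 to compound 4 (0.07 log units; that floor lies within the scatter), the first step measured at this nitrogen, and it reveals no gain in inhibition. Going by these compounds, compound 4 gives > 20000 nM, which is a limit and not a number, so the true size of the step stays unknown and could be small or large. Only compound 3 now carries a number, and the series sits almost wholly at the edge of the read-out: the limit of > 20000 nM in this assay, at which 3 of the 4 values shown sit.

On these data alone, how far compound 4 lies past the limit remains open, and so does any ranking of the benzoyl and benzyl groups. Also open, as far as these compounds go, is whether a free ring amine or a phenethyl group on that nitrogen would give a clear number in this assay.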